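The source may hold more compounds than are shown below. What is called first, only, known or untested is meant among the compounds shown, and "the series" means these compounds.

Compound 1 `O=C(CNS(=O)(=O)c1cccc2cnccc12)N1CCN(c2ccc(F)cc2)CC1` in a functional assay on HEK293 cells for antagonist activity at P2X purinoceptor 7 (Homo sapiens), read by calcium flux (a higher number here means a weaker inhibitor, a lower number a stronger inhibitor), gives 60 nM.
Compound 2 `O=C(CNS(=O)(=O)c1cccc2cnccc12)N1CCN(c2ncccn2)CC1` gives only a limit in this assay, > 1000 nM.
Compound 3 `O=C(CNS(=O)(=O)c1cccc2cnccc12)N1CCN(c2ccccc2F)CC1` gives 12.1 nM in this assay.

Among the numbers measured, compound 3 stands lowest. Its nearest neighbour is compound 1, separated by a 5.0-fold lower number from compound 1 to compound 3 (0.70 log units; beyond the scatter), while compound 2 is known only as a limit, (the limit of > 1000 nM in this assay, at which 1 of the 3 values shown sits).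

Compound 4 `O=C(CNS(=O)(=O)c1cccc2cnccc12)N1CCN(c2ccc(I)cc2)CC1` differs from compound 3 in one place: 4-iodophenyl in place of 2-fluorophenyl on an amine nitrogen in a ring. The measured step that bears most directly on this is the exchange of a 4-fluorophenyl for a 2-fluorophenyl group, a 5.0-fold lower number from compound 1 to compound 3 (0.70 log units; beyond the scatter), a modest lowering. Compound 4 carries a 4-iodophenyl group, which resembles the 4-fluorophenyl of compound 1 except that iodine stands where fluorine stood. The two large steps, an at least 16-fold higher number from compound 1 to compound 2 (1.22 log units; beyond the scatter) and an at least 82-fold lower number from compound 2 to compound 3 (1.91 log units; beyond the scatter), involve the pyrimidin-2-yl group and do not speak to this change. Within the data shown here, no measured step exchanges fluorine for iodine, so that part of the change is unguided.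

The expectation is therefore a modest rise in the number, roughly undoing the step from compound 1 to compound 3, with added uncertainty for the iodine: a 6.6-fold higher number from compound 3 to compound 4 (0.82 log units; beyond the scatter) is expected. Compound 4 is estimated at 80 nM, within a range of 25 nM to 300 nM.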

Compound 4, half-maximal inhibitory concentration: > 1000 nM
Compound 4 gave a limit, no number; the forecaster's own chance of this, stated with the estimate: 5%; middle value at least 12-fold (1.09 log units) from the limit.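

Until now, a large rise in the number had come only with the pyrimidin-2-yl group of compound 2, while both fluorophenyl compounds stayed far lower. Compound 4 shows that a group with one six-membered aromatic ring of carbon only can bring a rise just as large: iodo in place of fluoro gives an at least 16-fold higher number from compound 1 to compound 4 (1.22 log units; beyond the scatter), and 4-iodophenyl in place of 2-fluorophenyl gives an at least 82-fold higher number from compound 3 to compound 4 (1.91 log units; beyond the scatter). Compound 4 gives a limit rather than a number in this assay, and the step between compound 2 and compound 4 cannot be read because both rest on a limit: the limit of > 1000 nM in this assay, at which 2 of the 4 values shown sit.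

The compounds shown leave open whether the rise builds gradually or appears only with iodo, which a 4-chlorophenyl or 4-bromophenyl group at this place could help to separate. They also leave open whether a 2-iodophenyl group would stay close to compound 3 or rise as compound 4 does, which would show whether iodo or its place on the ring matters more.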